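Swapping the group on the aromatic nitrogen

This account rests on a few compounds, and the source may have more. Where it says the series, first, only, none or still open, it means among the compounds named here.

Of the compounds shown here, three have been measured in a functional assay on CHO-K1 cells for antagonist activity at prostaglandin E2 receptor EP3 subtype (Homo sapiens), read by TR-FRET and cAMP accumulation, with a stated time of 30 min; on this read-out lower numbers stand for stronger inhibition and higher numbers for weaker inhibition. Among the compounds with values here, compound 1 `Cc1nc(C)c(S(=O)(=O)NC(=O)NC/C=C2\CCCc3cnn(Cc4ccc(Cl)cc4Cl)c32)s1` gives 4 nM and compound 2 `Cn1cc(S(=O)(=O)NC(=O)NC/C=C2\CCCc3cnn(Cc4ccc(Cl)cc4Cl)c32)cn1` gives 8 nM; the only single-point step, a 2.0-fold higher number from compound 1 to compound 2 (0.30 log units; within the scatter), sits on the sulfonyl sulfur. Compound 3 `CS(=O)(=O)c1ccc(-n2ncc3c2/C(=C/CNC(=O)NS(=O)(=O)c2cc(Cl)c(Cl)s2)CCC3)cc1` gives 30 nM, the highest of the three numbers, beyond the scatter from both others.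

Compound 4 `O=C(NC/C=C1\CCCc2cnn(Cc3ccc(Cl)cc3Cl)c21)NS(=O)(=O)c1cc(Cl)c(Cl)s1` differs from compound 3 in one place: 2,4-dichlorobenzyl in place of 4-(methylsulfonyl)phenyl on an aromatic nitrogen. Within the data shown here, no measured step bears directly on this change. What compound 1 and compound 2 show is that the 2,4-dichlorobenzyl group on the aromatic nitrogen goes with the lowest numbers seen, while compound 3 with 4-(methylsulfonyl)phenyl stands highest. A downward step is therefore expected, a 5.0-fold lower number from compound 3 to compound 4 (0.70 log units; beyond the scatter), beyond the scatter. Compound 4 is estimated at 6 nM, with a range from 2 nM to 18 nM.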

Compound 4, half-maximal inhibitory concentration: 11 nM
The estimate for compound 4 lay 1.8-fold (0.26 log units) below the measured number; the range from low to high includes it.
By their numbers in this assay, from the lowest: compounds 1, 2 and 4 (each within the scatter of the next, the first and the last beyond it); then compound 3.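

In this assay, the change on the aromatic nitrogen can now be read directly: 2,4-dichlorobenzyl in place of 4-(methylsulfonyl)phenyl gives a 2.7-fold lower number from compound 3 to compound 4 (0.44 log units; beyond the scatter), a modest step. The sulfonyl sulfur also matters, since 4,5-dichlorothiophen-2-yl gives a 1.4-fold higher number from compound 2 to compound 4 (0.14 log units; within the scatter) when it replaces 1-methyl-1H-pyrazol-4-yl, but a 2.8-fold higher number from compound 1 to compound 4 (0.44 log units; beyond the scatter) when it replaces 2,4-dimethyl-1,3-thiazol-5-yl. No supporting data explain the size of these steps.

From the compounds shown here alone, whether the step on the aromatic nitrogen holds with other groups on the sulfonyl sulfur remains open. So does the effect of an amine, a carboxylic acid or a longer alkyl chain in place of 2,4-dichlorobenzyl.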